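This account rests on a few compounds, and the source may have more. Where it says the series, first, only, none or still open, it means among the compounds named here.

Measured so far in a functional assay on 786-0 cells (Homo sapiens) for inhibition, read by sulforhodamine B assay, with a stated time of 48 h; a lower number here means a stronger inhibitor of growth, a higher number a weaker inhibitor of growth:

- Compound 1 `CCOC(=O)c1nn(-c2ccccc2)c(-c2ccc(F)cc2)c1CNC(C)(C)C`: > 632000 nM; 319000 nM (2 entries)
- Compound 2 `CCOC(=O)c1nn(-c2ccccc2)c(-c2ccc(Br)cc2)c1CNC(C)(C)C`: 83900 nM; > 509000 nM (2 entries)
- Compound 3 `CC(C)(C)NCc1c(C(=O)O)nn(-c2ccccc2)c1-c1ccc(F)cc1`: > 680000 nM

For compound 3, the only result, > 680000 nM, is a limit and not a number. Compound 4 `CC(C)(C)NCc1c(C(=O)O)nn(-c2ccccc2)c1-c1ccc(Br)cc1` differs from compound 3 in one place: bromo in place of fluoro on an aromatic carbon. This is bromo in place of fluoro on an aromatic carbon, para to a large group.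

For the measured compounds named here, no measured pair gives a direct size for this change. Compound 1, which carries fluoro, gives > 632000 nM; 319000 nM (2 entries). Compound 2, which carries bromo, gives 83900 nM; > 509000 nM (2 entries). These mixed entries give only weak grounds to expect stronger growth inhibition with bromo, so no step beyond the scatter is expected in this assay.

The expected change an at least 1.3-fold lower number from compound 3 to compound 4 (0.13 log units; that floor lies within the scatter) is small. The estimate for compound 4 is 500000 nM, with an expected range of 150000 nM to 800000 nM.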

Compound 4, concentration for 50% growth inhibition: > 585000 nM
Compound 4: no number, only a limit; the forecaster's own chance of this, stated with the estimate: 65%; at least 1.1-fold (0.06 log units) between middle value and limit.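

In this assay, for the compounds shown here, compound 3 and compound 4 each give only a limit and not a number, so no step between them can be read. The compounds shown leave open whether bromo in place of fluoro changes growth inhibition in this pair at all, and by how much.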